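This account rests on a few compounds, and the source may have more. Where it says the series, first, only, none or still open, it means among the compounds named here.

Series notes, a functional assay on MIA PaCa-2 cells (Homo sapiens) for inhibition, read by MTT assay, with a stated time of 3 days; on this read-out higher numbers stand for weaker inhibition and lower numbers for stronger inhibition:

- compound 1, `CCN(CC)S(=O)(=O)c1ccc(S(=O)(=O)N2CCC[C@@H](C(=O)N3CCC(O)CC3)C2)cc1`: 230 nM
- compound 2, `CCN(CC)S(=O)(=O)c1ccc(S(=O)(=O)N2CCC[C@@H](C(=O)N3CCC(C(F)(F)F)CC3)C2)cc1`: 110 nM
- compound 3, `CCN(CC)S(=O)(=O)c1ccc(S(=O)(=O)N2CCC[C@@H](C(=O)N3CCC(OC)CC3)C2)cc1`: 50 nM
- compound 4, `CCN(CC)S(=O)(=O)c1ccc(S(=O)(=O)N2CCC[C@@H](C(=O)N3CC[C@H](OC)C3)C2)cc1`: not yet measured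

Compound 3 holds the lowest number of the three in this assay; the gaps to the other two are beyond the scatter, so within this small set it is the most potent. The measured steps all change the group on the saturated ring carbon of the amide-linked ring: a 2.1-fold lower number from compound 1 to compound 2 (0.32 log units; beyond the scatter), a 4.6-fold lower number from compound 1 to compound 3 (0.66 log units; beyond the scatter) and a 2.2-fold lower number from compound 2 to compound 3 (0.34 log units; beyond the scatter). Each is modest, and together they show that this part of the molecule shifts the read-out by small amounts only.

Compound 4 differs from compound 3 by 3-methoxypyrrolidin-1-yl in place of 4-methoxypiperidin-1-yl on a carbonyl carbon. Among the measured compounds shown here, no measured step changes the size of this ring, so nothing bears directly on it; the three steps only show that modest shifts are the rule here. The expectation is therefore a small step, a 1.6-fold higher number from compound 3 to compound 4 (0.20 log units; within the scatter), if any beyond the scatter, with a slight lean towards a higher number. Compound 4 is estimated at 80 nM in this assay, expected between 30 nM and 250 nM.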

Compound 4, half-maximal inhibitory concentration: 460 nM
The estimate for compound 4 lay 5.8-fold (0.76 log units) below the measured number; the whole stated range lies below it.
By their numbers in this assay, from the lowest: compound 3; then compound 2; then compounds 1 and 4 (each within the scatter of the next).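

In this assay, among the compounds shown here, the group on the carbonyl carbon proves sensitive to the ring itself: 3-methoxypyrrolidin-1-yl in place of 4-methoxypiperidin-1-yl gives a 9.2-fold higher number from compound 3 to compound 4 (0.96 log units; beyond the scatter), the widest step so far. The same group also falls behind the trifluoromethyl-bearing piperidine, with a 4.2-fold higher number from compound 2 to compound 4 (0.62 log units; beyond the scatter), while a 2.0-fold higher number from compound 1 to compound 4 (0.30 log units; within the scatter) stays within the scatter, so the five-membered ring cancels the advantage of methoxy over hydroxy seen on the six-membered ring. Nothing at hand accounts for this step.

The compounds shown leave open whether ring size or the placing of the methoxy group drives the change, a question that 3-methoxypiperidin-1-yl would separate. On these data alone, the role of the defined stereocentre also stays open, and the opposite stereoisomer of 3-methoxypyrrolidin-1-yl would address it.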